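This account rests on a few compounds, and the source may have more. Where it says the series, first, only, none or still open, it means among the compounds named here.

Measured compounds:
- compound 1 `CC1CCN(C2CCN(S(=O)(=O)c3cccnc3Cl)CC2)CC1`: > 10000 nM
- compound 2 `CC1CCN(C2CCN(S(=O)(=O)c3cc(F)c(Br)c(F)c3)CC2)CC1`: > 5000 nM

In an ADME assay on HCT-116 cells (Homo sapiens) for cytotoxicity, read by CellTiter-Glo, with a stated time of 72 h (on this read-out lower numbers stand for stronger inhibition and higher numbers for weaker inhibition), compound 1 reaches only a limit, (the limit of > 10000 nM in this assay, at which 1 of the 2 values shown sits), and no number. Compound 2, in the same assay, likewise reaches only a limit, (the limit of > 5000 nM in this assay, at which 1 of the 2 values shown sits). On the numbers shown, compound 1 therefore stands nowhere in particular: both values are limits, and nothing separates compound 1 from compound 2 beyond the fact that each is a limit. Compound 3 `CC1CCN(C2CCN(S(=O)(=O)c3ccc(Br)c(Cl)c3)CC2)CC1` has not been measured in this assay. It differs from compound 1 in one place: 4-bromo-3-chlorophenyl in place of 2-chloropyridin-3-yl on a sulfonyl sulfur. Going by the values given here, no measured pair differs in a single place here, so the size of this step cannot be read from data. Given that compound 1 sits at a limit, the expected step that the limit leaves unreadable from compound 1 to compound 3 is none beyond the usual scatter. Compound 3 is accordingly expected to give about 15000 nM, within 5000 nM to 50000 nM, most likely again as a limit.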

Compound 3, half-maximal inhibitory concentration: > 5000 nM
Compound 3 was reported as a limit; the forecaster's own chance of this, stated with the estimate: 85%; the middle value is on the limit's open side.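

In this assay compound 1 gives only a limit, > 10000 nM. Compound 3 likewise gives only a limit, > 5000 nM. These two limits leave the step from compound 1 to compound 3 unreadable. The compounds shown leave open what 4-bromo-3-chlorophenyl in place of 2-chloropyridin-3-yl does to the read-out, and whether any of them would give a number.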